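This account rests on a few compounds, and the source may have more. Where it says the series, first, only, none or still open, it means among the compounds named here.

Measured compounds:
compound 1, `FC(F)(F)c1ccc(Nc2ncnc3sc(Nc4c(Cl)cccc4Cl)nc23)cc1Cl`, 21 nM
compound 2, `Cc1nc(Nc2ccc(C(F)(F)F)c(Cl)c2)c2nc(Nc3c(Cl)cccc3Cl)sc2n1`, 3 nM

In a functional assay on HEK293 cells for antagonist activity at transient receptor potential cation channel subfamily V member 1 (Homo sapiens), read by calcium flux (a higher number here means a weaker inhibitor, a lower number a stronger inhibitor), compound 2 gives the lowest of the two numbers; its nearest neighbour is compound 1, and the step of a 7.0-fold lower number from compound 1 to compound 2 (0.85 log units; beyond the scatter) lies beyond the scatter. Compound 3, `CSc1nc(Nc2ccc(C(F)(F)F)c(Cl)c2)c2nc(Nc3c(Cl)cccc3Cl)sc2n1`, has not been measured. It differs from compound 2 by methylsulfanyl in place of methyl on an aromatic carbon. Going by the values given here, only the step from hydrogen to methyl at that carbon bears on this change, and no comparison of methyl against methylsulfanyl exists among the measured compounds. Compound 3 is therefore expected to stay close to compound 2, with a 1.3-fold higher number from compound 2 to compound 3 (0.12 log units; within the scatter) not beyond the scatter. The estimate for compound 3 is 4 nM, within 1.5 nM to 12 nM.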

Compound 3, half-maximal inhibitory concentration: 224 nM
Compound 3: middle estimate off by 56-fold (1.75 log units), on the low side; the whole stated range lies below it.
By their numbers in this assay, from the lowest: compound 2; then compound 1; then compound 3.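

Replacing methyl with methylsulfanyl on the carbon between two ring nitrogen atoms gives a 75-fold higher number from compound 2 to compound 3 (1.87 log units; beyond the scatter) in this assay and shows that this position does not accept every small group alike. Set against hydrogen at that carbon, methylsulfanyl gives an 11-fold higher number from compound 1 to compound 3 (1.03 log units; beyond the scatter) and so reverses the direction of the gain seen with methyl. Nothing available explains this reversal. The compounds shown leave open whether the loss goes with the sulfur atom or with the longer substituent. How a methoxy or an ethyl group at this carbon would read remains an open question.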